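Swapping the halogenated phenyl ring on a spiro-fused scaffold

This account rests on a few compounds, and the source may have more. Where it says the series, first, only, none or still open, it means among the compounds named here.

Compound 1, with the structure `N#CC1=C(N)Oc2c(c3nc4ccccc4nc3c3ccccc23)C12C(=O)N(Cc1cnnn1-c1cccc(Br)c1)c1ccccc12`, was tested in a functional assay on HepG2 cells (Homo sapiens) for antiproliferative activity, read by MTT assay, with a stated time of 48 h; a lower number here means a stronger inhibitor, a higher number a weaker inhibitor. In this assay compound 1 gives > 50000 nM, which is a limit of the assay rather than a measured number. Compound 2, with the structure `COc1ccc(-n2nncc2CN2C(=O)C3(C(C#N)=C(N)Oc4c3c3nc5ccccc5nc3c3ccccc43)c3ccccc32)cc1`, differs from compound 1 only by carrying a 4-methoxyphenyl in place of a 3-bromophenyl on an aromatic nitrogen. In this assay compound 2 also gives > 50000 nM, again a limit and not a number. The step that the two limits leave unreadable from compound 1 to compound 2 therefore cannot be read, since both ends sit at the same limit, as summarised by the limit of > 50000 nM in this assay, at which 2 of the 2 values shown sit.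

Compound 3, with the structure `N#CC1=C(N)Oc2c(c3nc4ccccc4nc3c3ccccc23)C12C(=O)N(Cc1cnnn1-c1ccc(Cl)c(Cl)c1)c1ccccc12`, is not yet measured. It differs from compound 1 as follows: 3,4-dichlorophenyl in place of 3-bromophenyl on an aromatic nitrogen. For the measured compounds named here, only the one unreadable step bears on this change, and it gives no direction. Both measured compounds sit at the limit, so the expectation for compound 3 is that it stays there too, with a step that the limit leaves unreadable from compound 1 to compound 3 expected. Compound 3 is thus estimated at 70000 nM, with a range from 20000 nM to 250000 nM.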

Compound 3, half-maximal inhibitory concentration: > 50000 nM
Compound 3 was reported as a limit; the forecaster's own chance of this, stated with the estimate: 85%; the middle value is on the limit's open side.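

In this assay compound 3 gives > 50000 nM, which is a limit of the assay and not a number. The steps to compound 3 from compound 1 and compound 2 therefore cannot be read: the limit of > 50000 nM in this assay, at which 3 of the 3 values shown sit.

The compounds shown leave open whether any other ring on that aromatic nitrogen would give a measurable value.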